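From compound 2 to its fluoro analogue, compound 3

This account rests on a few compounds, and the source may have more. Where it says the series, first, only, none or still open, it means among the compounds named here.

Compounds measured in a functional assay on A549 cells (Homo sapiens) for inhibition, read by MTT assay, with a stated time of 72 h; on this read-out lower numbers stand for stronger inhibition and higher numbers for weaker inhibition
Compound 1 (`CC/C=C\C(=O)Nc1cc(Nc2nc3c(c(-c4cn(C)c5ccccc45)n2)CS(=O)(=O)CC3)c(OC)cc1N(C)CCN(C)C`) gives 1350 nM
Compound 2 (`CCC/C=C\C(=O)Nc1cc(Nc2nc3c(c(-c4cn(C)c5ccccc45)n2)CS(=O)(=O)CC3)c(OC)cc1N(C)CCN(C)C`) gives 57 nM

Compound 2 holds the lower of the two numbers in this assay and is the starting point here. Compound 3 (`CCC/C=C\C(=O)Nc1cc(Nc2nc3c(c(-c4cn(C)c5ccc(F)cc45)n2)CS(=O)(=O)CC3)c(OC)cc1N(C)CCN(C)C`) differs from it as follows: fluoro in place of hydrogen on an aromatic carbon. Within the data shown here, the only measured step, a 24-fold lower number from compound 1 to compound 2 (1.37 log units; beyond the scatter) (large), lies on a saturated chain carbon, so no measured step covers this aromatic change. It does show that a single-atom change can move this number far, which widens the range. The expected change, a 1.1-fold higher number from compound 2 to compound 3 (0.02 log units; within the scatter) (estimated), is none beyond the scatter. For compound 3 the estimated value is 60 nM (expected range 20 nM to 180 nM).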

Compound 3, half-maximal inhibitory concentration: 7570 nM
Compound 3: middle estimate off by 130-fold (2.10 log units), on the low side, outside the stated range (above it).
By their numbers in this assay, from the lowest: compound 2; then compound 1; then compound 3.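

In this assay the aromatic carbon of the 5-fluoro-1-methyl-1H-indol-3-yl group turns out to matter strongly: fluoro in place of hydrogen gives a 130-fold higher number from compound 2 to compound 3 (2.12 log units; beyond the scatter) and so reverses, in the opposite direction, a change as large as a 24-fold lower number from compound 1 to compound 2 (1.37 log units; beyond the scatter) on the chain. The number therefore responds to this aromatic position as well as to the chain. Nothing available here explains this step. The compounds shown leave open whether the loss is particular to fluoro or would also follow a chloro or methoxy group on the same carbon.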